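Changing the Ester Group of Compound 2

A few compounds are considered here, and "the series" means these few. Any claim that something is new, unique, unknown or untested is made for them only; others in the source may bear on it.

Compound 1, `C=CC(=O)NC/C=C/c1cc(OC)cc(O)c1C(=O)OC(C)C`: > 10000 nM
Compound 2, `C=CS(=O)(=O)NC/C=C/c1cc(OC)cc(O)c1C(=O)OCc1ccc(Br)cc1`: 6060 nM

Of the compounds shown here, two have so far been tested in a functional assay on MV4-11 cells (Homo sapiens) for antiproliferative activity, read by luminescence, with a stated time of 72 h; on this read-out higher numbers stand for weaker inhibition and lower numbers for stronger inhibition. For compound 1 the result, > 10000 nM, is a limit of the assay and not a number, as the note the limit of > 10000 nM in this assay, at which 1 of the 2 values shown sits, records. Within the data shown here, compound 2 is therefore the only compound with a measured number in this assay, where compound 2 gives 6060 nM. Among the measured compounds shown here, no pair of measured compounds differs in just one place, so no measured step is available to guide expectations.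

Compound 3 `C=CS(=O)(=O)NC/C=C/c1cc(OC)cc(O)c1C(=O)OCC(C)c1ccccc1` is the next compound to be measured. It differs from compound 2 as follows: 1-phenylethyl in place of 4-bromophenyl on a saturated chain carbon bound to an oxygen next to a carbonyl group. Nothing in the two measured values speaks for or against this change, so the step from compound 2 to compound 3 is expected to be small, with a 1.2-fold higher number from compound 2 to compound 3 (0.06 log units; within the scatter) lying within the scatter of this assay. Compound 3 is estimated at 7000 nM, with a likely range from 2000 nM to 25000 nM.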

Compound 3, half-maximal inhibitory concentration: 7730 nM
Beside the measured number, compound 3's estimate is 1.1-fold (0.04 log units) below it; the range from low to high includes it.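

In this assay, among these compounds, 1-phenylethyl in place of 4-bromophenyl on a saturated chain carbon bound to an oxygen next to a carbonyl group gives a 1.3-fold higher number from compound 2 to compound 3 (0.11 log units; within the scatter), the first step that can be read. At this position the two groups cannot be told apart, although the bromine is gone and the group entering has only carbon among its heavy atoms, while the one aromatic ring of carbon only remains in both. Nothing measured here offers an explanation for this result.

Going by these compounds, it remains open whether an amine or a carboxylic acid on that aromatic ring, or a longer chain in place of 2-phenylpropyl, would carry the number beyond the scatter. On these data alone, compound 1 differs from the other compounds in more than one place, so what its limit says about this position also stays open.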